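The source may report more compounds than this note shows. Statements on the series, on what has been measured and on what is new or still open speak of the compounds shown alone.

Measured compounds in a functional assay on BXPC-3 cells (Homo sapiens) for antiproliferative activity, read by MTT assay, with a stated time of 24 h; a lower number here means a stronger inhibitor, a higher number a weaker inhibitor:

compound 1 `CCn1c(C(=O)NCCO)ccc1C(CC)(CC)c1ccc(OCS(=O)(=O)c2ccccc2)c(C)c1` gives 19900 nM
compound 2 `CCn1c(C(=O)N[C@H](C)CO)ccc1C(CC)(CC)c1ccc(OCS(=O)(=O)c2ccccc2)c(C)c1` gives 10000 nM
compound 3 `CCn1c(C(=O)N[C@@H](C)C(=O)O)ccc1C(CC)(CC)c1ccc(OCS(=O)(=O)c2ccccc2)c(C)c1` gives 20800 nM

All three share one core and differ only in the group on the amide-type nitrogen. Compound 2 and compound 3 differ by 1-carboxyethyl in place of 1-(hydroxymethyl)ethyl on an amide-type nitrogen, a step of a 2.1-fold higher number from compound 2 to compound 3 (0.32 log units; beyond the scatter). Compound 1 and compound 3 sit together, a 1.0-fold higher number from compound 1 to compound 3 (0.02 log units; within the scatter). The change from compound 2 to compound 1 is hydrogen in place of methyl on a saturated chain carbon bound to an amide-type nitrogen and a saturated chain carbon, and it gave a 2.0-fold higher number from compound 2 to compound 1 (0.30 log units; within the scatter).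

Compound 4 `CCn1c(C(=O)NCC(=O)O)ccc1C(CC)(CC)c1ccc(OCS(=O)(=O)c2ccccc2)c(C)c1`, not yet measured, arises from compound 3 by hydrogen in place of methyl on a saturated chain carbon bound to an amide-type nitrogen and a carbonyl carbon. This is the same kind of change as that from compound 2 to compound 1, but not the same: there the carbon carrying the methyl is bound to an amide-type nitrogen and a saturated chain carbon, here to an amide-type nitrogen and a carbonyl carbon. Resting on compound 3 at 20800 nM and on the earlier step of a 2.0-fold higher number from compound 2 to compound 1 (0.30 log units; within the scatter), a step of similar size, a 1.5-fold higher number from compound 3 to compound 4 (0.19 log units; within the scatter), is expected, with the second occurrence in the series too sparse to carry more weight. Compound 4 is estimated at 32000 nM, most likely between 12000 nM and 80000 nM.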

Compound 4, half-maximal inhibitory concentration: > 50000 nM
Compound 4: a limit, no number; the forecaster's own chance of this, stated with the estimate: 15%; middle value at least 1.5-fold (0.19 log units) away from the limit.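

In this assay compound 4 gives > 50000 nM, which is a limit of the assay and not a number: the limit of > 50000 nM in this assay, at which 1 of the 4 values shown sits. Hydrogen in place of methyl on the carbon bound to the amide-type nitrogen and the carbonyl carbon gives an at least 2.4-fold higher number from compound 3 to compound 4 (0.38 log units; beyond the scatter), and the other two new steps, both also bounded by that limit, are an at least 5.0-fold higher number from compound 2 to compound 4 (0.69 log units; beyond the scatter) and an at least 2.5-fold higher number from compound 1 to compound 4 (0.40 log units; beyond the scatter). The result shows that the change does not lower the number on either core, but it does not show that the change has the same size on both, so carrying a step size from one core to the other is neither supported nor ruled out: the same change on two cores in this assay, a 2.0-fold higher number (0.30 log units; within the scatter) from compound 2 to compound 1 and an at least 2.4-fold higher number (0.38 log units; beyond the scatter) from compound 3 to compound 4; the limit leaves it open whether they differ.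

As far as these compounds go, the actual size of the step from methyl to hydrogen on the carboxylic acid side stays unknown while compound 4 has only a limit. Also open, from the compounds shown here alone, is how an amine or a longer chain ending in hydroxy or carboxylic acid on the amide-type nitrogen would read against these four compounds.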